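Lengthening the nitrile tether of compound 3

This account rests on a few compounds, and the source may have more. Where it says the series, first, only, none or still open, it means among the compounds named here.

Measured so far:
compound 1, `CC(=O)c1cc(CC2CO2)c(OCCCCC#N)cc1O`, gives 24% in an assay on isolated protein for binding affinity to leukotriene B4 receptor 1 (Homo sapiens), tested at 1 uM; a higher number here means more inhibition at the concentration tested (going by the name of the read-out), a lower number less inhibition.
compound 2, `CC(=O)c1cc(C(C)=O)c(OCCCCC#N)cc1O`, gives 0% in this assay.
compound 3, `C=CCc1cc(C(C)=O)c(O)cc1OCCCCC#N`, gives 57% in this assay.

Compound 3 stands highest of the three numbers: the step of a number 33 percentage points higher from compound 1 to compound 3 (beyond the scatter) is large, and the step of a number 57 percentage points higher from compound 2 to compound 3 (beyond the scatter) is larger still. The third step, a number 24 percentage points lower from compound 1 to compound 2 (beyond the scatter), runs the other way and is modest. All three steps change a substituent on the aromatic ring; none of them touches the cyanoalkyl chain on the ether oxygen.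

Compound 4, `C=CCc1cc(C(C)=O)c(O)cc1OCCCCCCCCC#N`, keeps the ring substitution of compound 3 and differs only in that chain: 4-cyanobutyl in place of cyano on a saturated chain carbon, four bonds along the chain from an oxygen on an aromatic ring. Within the data shown here, no measured step bears on this part of the molecule, so there is nothing to say whether a longer chain raises or lowers the read-out. The expectation therefore rests on compound 3 alone, and the step expected is a number 2 percentage points lower from compound 3 to compound 4 (within the scatter), that is, no change beyond the scatter, with a wide allowance either way given the absence of any comparable step.

For compound 4 the estimate in this assay is 55%, with a range from 30% to 78%.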

Compound 4, a percentage reported as inhibition, at one concentration (the size of the read-out at that concentration, not a potency): 50%
Compound 4: the middle estimate sits 5 percentage points above what was measured; the measured number falls inside the stated range.
By their numbers in this assay, from the lowest: compound 2; then compound 1; then compounds 4 and 3 (each within the scatter of the next).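

Among these compounds, this is the first step on the cyanoalkyl chain rather than on the ring substituents. In this assay, 4-cyanobutyl in place of cyano, four bonds along the chain from an oxygen on an aromatic ring, gives a number 7 percentage points lower from compound 3 to compound 4 (within the scatter) even though the entering group has 6 heavy atoms against 2 for the group it replaces. Across the compounds shown, the change on the ring in a number 57 percentage points higher from compound 2 to compound 3 (beyond the scatter) is large, whereas this chain extension leaves compound 3 and compound 4 indistinguishable, and no available evidence accounts for either result.

As far as these compounds go, two compounds give one chain comparison only, so the behaviour of the read-out with a still longer chain, or with a chain shorter than that of compound 3, remains open, as does the role of the nitrile, which a carboxylic acid or a primary amide in place of cyano would test. Also open, from the compounds shown here alone, is whether allyl in place of acetyl on the aromatic carbon gives a similar step when the chain is the longer one of compound 4.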